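A few compounds are considered here, and "the series" means these few. Any claim that something is new, unique, unknown or untested is made for them only; others in the source may bear on it.

Measured compounds:
- compound 2, `Nc1nc(-c2cccs2)cn1/N=C/c1cc2ccccc2nc1Cl`: 10200 nM
- compound 1, `Cc1ccc2nc(Cl)c(/C=N/n3cc(-c4ccccc4)nc3N)cc2c1`: 41500 nM

Among the compounds with values here, in an ADME assay on HUVEC cells (Homo sapiens) for cytotoxicity, read by MTT assay, with a stated time of 48 h (a lower number here means a stronger inhibitor, a higher number a weaker inhibitor), compound 2 gives 10200 nM, the lowest of the two numbers so far. Compound 1 gives 41500 nM in this assay, a higher number than compound 2 by a margin beyond the scatter. Within the data shown here, the two compounds differ in more than one place, so no single step between them is isolated; their values only show that compound 1 sits well above compound 2.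

Compound 3, `Cc1ccc2nc(Cl)c(/C=N/n3cc(-c4cccs4)nc3N)cc2c1`, is compound 2 with one change: methyl in place of hydrogen on an aromatic carbon. Among the measured compounds shown here, no pair of measured compounds shows this change on its own, so there is no directly comparable step. With a single carbon added and the rest of the structure of compound 2 retained, the expectation is a step of no size beyond the scatter, if anything a slightly higher number. The estimated step from compound 2 to compound 3 is a 1.5-fold higher number from compound 2 to compound 3 (0.17 log units; within the scatter). Compound 3 is expected to give 15000 nM in this assay, within a range of 6000 nM to 40000 nM.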

Compound 3, half-maximal inhibitory concentration: 38000 nM
Estimate against measurement, compound 3: 2.5-fold (0.40 log units) below, and the stated range covers the measured number.
By their numbers in this assay, from the lowest: compound 2; then compounds 3 and 1 (each within the scatter of the next).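

In this assay, within the data shown here, methyl in place of hydrogen on the six-membered aromatic ring of carbon only, meta to a fused ring and para to a fused ring, gives a modest step beyond the scatter (a 3.7-fold higher number from compound 2 to compound 3 (0.57 log units; beyond the scatter)), the first single change to be read on its own. With that methyl present, thiophen-2-yl in place of phenyl gives a step within the scatter (a 1.1-fold lower number from compound 1 to compound 3 (0.04 log units; within the scatter)), so along the path through compound 3 the gap between compound 2 and compound 1 lies on the methyl step and not on the aryl step. No measurement at hand bears on what lies behind the methyl step.

From the compounds shown here alone, whether a larger or different group at this place, such as ethyl, methoxy or chlorine, moves the number as methyl does remains open, as does the size of any step from a primary amine or a carboxylic acid there. Also open, going by these compounds, is whether thiophen-2-yl and phenyl stay this close on the core without the methyl, since the aryl step has been read only with methyl present.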